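Swapping an aryl group for a thiazole on a cytotoxic enol

This account rests on a few compounds, and the source may have more. Where it says the series, first, only, none or still open, it means among the compounds named here.

Three compounds that share one core and differ only in the aromatic group at the end of the chain have been tested in a functional assay on KB cells (Homo sapiens) for cytotoxicity; a lower number here means that less compound is needed, a higher number that more compound is needed for the effect. Compound 1 `COC1=C(C)C(=O)/C(=C(O)/C=C/c2ccccc2OC)C(=O)C1(C)C` gives 3.3 ug/mL; compound 2 `COC1=C(C)C(=O)/C(=C(O)/C=C/c2ccc(C)cc2)C(=O)C1(C)C` gives 3.9 ug/mL; compound 3 `COC1=C(C)C(=O)/C(=C(O)/C=C/c2cccs2)C(=O)C1(C)C` gives 5.5 ug/mL. Going by the values given here, compound 1 has the smallest number of the three, but the steps from it are small: a 1.2-fold higher number from compound 1 to compound 2 (0.07 log units; within the scatter) and a 1.7-fold higher number from compound 1 to compound 3 (0.22 log units; within the scatter), and between the other two a 1.4-fold higher number from compound 2 to compound 3 (0.15 log units; within the scatter), so no compound can be set apart from the others.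

Compound 4 `COC1=C(C)C(=O)/C(=C(O)/C=C/c2nccs2)C(=O)C1(C)C` has not yet been measured. It differs from compound 1 in one place: 1,3-thiazol-2-yl in place of 2-methoxyphenyl on a double-bonded chain carbon bound to a double-bonded chain carbon. The closest comparison is the move to a five-membered ring containing sulfur in compound 3, which gave a 1.7-fold higher number from compound 1 to compound 3 (0.22 log units; within the scatter). On that basis a similarly small step, if any, is expected for compound 4, so for compound 4 the estimate is 5 ug/mL, within a range of 2.5 ug/mL to 10 ug/mL, which corresponds to an expected step of a 1.5-fold higher number from compound 1 to compound 4 (0.18 log units; within the scatter).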

Compound 4, concentration for half-maximal effect: 4.3 ug/mL
Compound 4: the middle estimate sits 1.2-fold (0.07 log units) above what was measured; the measured number falls inside the stated range.
By their numbers in this assay, from the lowest: compounds 1, 2, 4 and 3 (each within the scatter of the next).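

The 1,3-thiazol-2-yl group is the only ring of the four with nitrogen in it, and in this assay it cannot be told apart from the other three end groups (a 1.3-fold higher number from compound 1 to compound 4 (0.11 log units; within the scatter); a 1.1-fold higher number from compound 2 to compound 4 (0.04 log units; within the scatter); a 1.3-fold lower number from compound 3 to compound 4 (0.11 log units; within the scatter)). Across these compounds, then, neither a five-membered ring with 2 hetero atoms in place of a six-membered aromatic ring of carbon only, nor 1,3-thiazol-2-yl in place of thiophen-2-yl, gives a difference larger than the scatter. Nothing measured here explains why these rings give such similar numbers.

From the compounds shown here alone, all four end groups are aromatic rings, so it remains open whether the same position, on a double-bonded chain carbon, would take an amine, a carboxylic acid or a longer chain without a larger step.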